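This account rests on a few compounds, and the source may have more. Where it says the series, first, only, none or still open, it means among the compounds named here.

Of the compounds shown here, three of this small series have been measured in a functional assay on LNCaP cells (Homo sapiens) for antiproliferative activity, read by propidium iodide staining, with a stated time of 96 h; on this read-out higher numbers stand for weaker inhibition and lower numbers for stronger inhibition. Compound 1 `CC(O)(CSc1ccc(C(F)(F)F)cc1)C(=O)Nc1ccc(S(F)(F)(F)(F)F)cc1` gives 17000 nM in this assay. Compound 2 `CC(O)(CSc1cccc(C(F)(F)F)c1)C(=O)Nc1ccc(S(F)(F)(F)(F)F)cc1` differs from compound 1 by 3-(trifluoromethyl)phenyl in place of 4-(trifluoromethyl)phenyl on a sulfur; in this assay compound 2 gives 18300 nM, so that the step of a 1.1-fold higher number from compound 1 to compound 2 (0.03 log units; within the scatter) is no more than the usual scatter of such measurements. Compound 3 `CC(O)(CS(=O)(=O)c1ccc(C(F)(F)F)cc1)C(=O)Nc1ccc(S(F)(F)(F)(F)F)cc1` has a core that differs from the core of compound 1 in more than one place; the difference between the two cores is not broken down here. In this assay compound 3 gives 20700 nM, a value that lies within the scatter of the values of compound 1 and compound 2, so no order among the three can be read from these numbers.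

Compound 4 `CC(O)(CS(=O)(=O)c1cccc(C(F)(F)F)c1)C(=O)Nc1ccc(S(F)(F)(F)(F)F)cc1` has not yet been measured. It differs from compound 3 by 3-(trifluoromethyl)phenyl in place of 4-(trifluoromethyl)phenyl on a sulfonyl sulfur. Going by the values given here, this is the same kind of change as the one from compound 1 to compound 2, though not the same change: in the measured pair the change sits on a sulfur whose other neighbours are a saturated chain carbon, whereas in compound 3 and compound 4 it sits on a sulfonyl sulfur whose other neighbours are a saturated chain carbon. The expectation for compound 4 therefore rests on the step of a 1.1-fold higher number from compound 1 to compound 2 (0.03 log units; within the scatter), which stayed within the scatter, and on the value of compound 3, 20700 nM. The step of a 1.1-fold higher number from compound 3 to compound 4 (0.03 log units; within the scatter) is what is expected, with the caution that the surroundings of the change are not identical. For compound 4 the estimate in this assay is 22000 nM, with a likely range from 12000 nM to 40000 nM.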

Compound 4, half-maximal inhibitory concentration: 21000 nM
The estimate for compound 4 lay 1.0-fold (0.02 log units) above the measured number; low and high end bracket the measured number.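

In this assay, 3-(trifluoromethyl)phenyl in place of 4-(trifluoromethyl)phenyl on a sulfonyl sulfur gives a 1.0-fold higher number from compound 3 to compound 4 (0.01 log units; within the scatter), so this change leaves no readable mark on the number when the sulfur is part of a sulfonyl group. This does not show that the change has no effect in general. Going by these compounds alone, the two pairs cover only a thioether sulfur and a sulfonyl sulfur, and with neither step beyond the scatter, they offer no effect of measurable size to follow from one core to the other; they show only that the change stayed within the scatter on both cores, and they say nothing about any further core. Set side by side, the two steps do not differ:  the same change on two cores in this assay, a 1.1-fold higher number (0.03 log units; within the scatter) from compound 1 to compound 2 and a 1.0-fold higher number (0.01 log units; within the scatter) from compound 3 to compound 4, 1.1-fold (0.03 log units) apart, within the scatter of two such steps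

The compounds shown leave open whether a nitrile, a chlorine or a methoxy group in place of the trifluoromethyl group on the phenyl ring would give a number beyond the scatter of this series. They also leave open how a sulfoxide at the sulfur, a longer chain in place of the saturated chain carbon on the sulfur, or an amine in place of the hydroxyl group would fare in this assay.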